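This account rests on a few compounds, and the source may have more. Where it says the series, first, only, none or still open, it means among the compounds named here.

Measured so far in a functional assay on ACHN cells (Homo sapiens) for inhibition; a lower number here means a stronger inhibitor of growth, a higher number a weaker inhibitor of growth:
Compound 1, `COc1cc(/C=C/C(=O)c2cccc(-n3cc(-c4ccc(Cl)cc4)[nH]c3=O)c2)cc(OC)c1OC`, gives 7170 nM.
Compound 2, `COc1ccc(-c2cn(-c3cccc(C(=O)/C=C/c4ccc(O)c(OC)c4)c3)c(=O)[nH]2)cc1`, gives 3400 nM.
Compound 3, `COc1ccc(-c2cn(-c3cccc(C(=O)/C=C/c4cc(OC)c(OC)c(OC)c4)c3)c(=O)[nH]2)cc1`, gives 1820 nM.

The three compounds share a core and differ at two ends. Between compound 3 and compound 2 the difference lies on the chain side: 4-hydroxy-3-methoxyphenyl in place of 3,4,5-trimethoxyphenyl on a double-bonded chain carbon bound to a double-bonded chain carbon. The step here is small; a 1.9-fold lower number from compound 2 to compound 3 (0.27 log units; within the scatter), so the two values show nothing beyond the usual scatter of this assay.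

Between compound 3 and compound 1 the change sits at the other end: chloro in place of methoxy on an aromatic carbon. This step is larger: a 3.9-fold higher number from compound 3 to compound 1 (0.60 log units; beyond the scatter), a modest but real loss of growth inhibition.

Compound 4, `COc1cc(/C=C/C(=O)c2cccc(-n3cc(-c4ccc(Cl)cc4)[nH]c3=O)c2)ccc1O`, has not yet been measured in this assay. It stands to compound 2 as compound 1 stands to compound 3: chloro in place of methoxy on an aromatic carbon. The place lines of the two changes read the same word for word, so this is the same change made on the other core. Among the compounds shown it occurs twice in all, once measured and once not.

Going by the values given here, compound 4 is therefore expected to follow the one measured example. It is estimated to give 11000 nM in this assay, with a range from 4500 nM to 27000 nM. That estimate means an expected step of a 3.2-fold higher number from compound 2 to compound 4 (0.51 log units; beyond the scatter), resting on compound 2 at 3400 nM and on the earlier step of a 3.9-fold higher number from compound 3 to compound 1 (0.60 log units; beyond the scatter). Since that single earlier step is the only basis, the range is kept wide.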

Compound 4, concentration for 50% growth inhibition: 2190 nM
Beside the measured number, compound 4's estimate is 5.0-fold (0.70 log units) above it; the measured number lies below the stated range.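

In this assay, putting chloro in place of methoxy on the core with the 4-hydroxy-3-methoxyphenyl chain end gives a 1.6-fold lower number from compound 2 to compound 4 (0.19 log units; within the scatter) and so leaves no difference that can be told from the usual scatter, whereas the same change on the core with the 3,4,5-trimethoxyphenyl chain end cost growth inhibition. The move from 4-methoxyphenyl to 4-chlorophenyl therefore did not carry over from one core to the other with the same size, and the two steps differ by more than their scatter allows: the same change on two cores in this assay, a 3.9-fold higher number (0.60 log units; beyond the scatter) from compound 3 to compound 1 and a 1.6-fold lower number (0.19 log units; within the scatter) from compound 2 to compound 4, 6.1-fold (0.79 log units) apart, beyond the scatter of two such steps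

This shows that, among these four compounds, the result of the change depends on which chain end is present, so a step read on one core is a poor guide to the other. Going by these compounds alone, it does not show what about the two chain ends produces the difference, and with only one pair on each core it cannot say which of the two steps is the more typical for the series.

The compounds shown leave open how other groups at this place, such as fluoro, a dimethylamino group or a carboxylic acid, would behave on either core. They also leave open whether a chain end carrying a single methoxy group, or a plain phenyl, would follow compound 1 or compound 4 when chloro replaces methoxy.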